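Methoxy for Chloro, Tried on a Second Core

The compounds below may be only part of what the source reports. "The series", "measured", "known", "first", "only" and "open" are said of these compounds alone.

Compound 1 `Cc1nc(-c2ccc(Cl)cc2)sc1C(=O)CSc1nc(-c2ccc(Cl)c(Cl)c2)c(C#N)c(=O)[nH]1` gives 101% in a functional assay on U-87MG ATCC cells for antiproliferative activity against U-87 MG (Homo sapiens), read by MTT assay, with a stated time of 48 h, tested at 5 uM; on this read-out lower numbers stand for a stronger effect and higher numbers for a weaker effect at the one concentration tested.
Compound 2 `COc1ccc(-c2nc(C)c(C(=O)CSc3nc(-c4ccc(Cl)c(Cl)c4)c(C#N)c(=O)[nH]3)s2)cc1` gives 101% in this assay.
Compound 3 `Cc1nc(-c2ccc(Cl)cc2)sc1C(=O)CSc1nc(N)c(C#N)c(-c2ccc(Cl)cc2)n1` gives 46.1% in this assay.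

Compound 1 and compound 2 share one core; the difference between the core of compound 3 and that of compound 1 is not broken down here. Compound 3 stands lowest of the three, beyond the scatter from both others. From compound 1 to compound 2 the change is methoxy in place of chloro on an aromatic carbon, and it made no change at the digits printed from compound 1 to compound 2 (within the scatter). Compound 4 `COc1ccc(-c2nc(SCC(=O)c3sc(-c4ccc(Cl)cc4)nc3C)nc(N)c2C#N)cc1` has not been measured; it differs from compound 3 by methoxy in place of chloro on an aromatic carbon, the same change at the same place. Because no change at the digits printed from compound 1 to compound 2 (within the scatter) showed the swap doing nothing on the first core, a small step is expected here too: a number 1.9 percentage points higher from compound 3 to compound 4 (within the scatter). This rests on one precedent on a different core. Compound 4 is accordingly expected to read 48%, between 30% and 70%.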

Compound 4, a percentage reported as activity, at one concentration (the size of the read-out at that concentration, not a potency): 69.7%
The estimate for compound 4 lay 21.7 percentage points below the measured number; the measured number falls inside the stated range.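

The swap of 4-chlorophenyl to 4-methoxyphenyl gave a number 23.6 percentage points higher from compound 3 to compound 4 (beyond the scatter) in this assay, and as lower numbers stand for a stronger effect, compound 4 has the weaker effect at the one concentration tested. Set beside the earlier step, the same change did not carry over from one core to the other at the same size: the same change on two cores in this assay, no change at the digits printed (within the scatter) from compound 1 to compound 2 and a number 23.6 percentage points higher (beyond the scatter) from compound 3 to compound 4, 23.6 percentage points apart, beyond the scatter of two such steps. This shows that a swap with no visible effect on one core can have one on another, but with a single pair on each core it does not show why the two differ or what a further core would do.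

The compounds shown leave open how an amine or a hydroxyl group would read in place of the chloro on the same aromatic carbon. Readings at one concentration also give no potency for any of these compounds.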